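Dimethylamino for methylsulfanyl on a shared amide-cinnamate core

The compounds below may be only part of what the source reports. "The series", "measured", "known", "first", "only" and "open" are said of these compounds alone.

Of the compounds shown here, two have numbers so far. Compound 1 `COC(=O)/C=C/c1cccc(N(Cc2ccc(/C=C/c3cccc(F)c3)cc2)C(=O)C2CCCCC2)c1` gives 86 nM in an assay on isolated protein with Bile acid receptor (Homo sapiens) as the target; a higher number here means that more compound is needed for the effect, a lower number that less compound is needed. Compound 2 `COC(=O)/C=C/c1cccc(N(Cc2ccc(-c3ccc(SC)cc3)cc2)C(=O)C(C)C)c1` gives 51 nM in this assay; the two values lie within the scatter of each other, so neither compound separates from the other.

Compound 3 `COC(=O)/C=C/c1cccc(N(Cc2ccc(-c3ccc(N(C)C)cc3)cc2)C(=O)C(C)C)c1` is not yet measured. It differs from compound 2 in one place: dimethylamino in place of methylsulfanyl on an aromatic carbon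

Within the data shown here, no measured step of this kind exists. A small step, if any, is expected a 1.2-fold higher number from compound 2 to compound 3 (0.07 log units; within the scatter) in this assay. For compound 3 the expected value in this assay is 60 nM, with a range from 20 nM to 180 nM.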

Compound 3, half-maximal effective concentration: 57 nM
Estimate against measurement, compound 3: 1.1-fold (0.02 log units) above; the range from low to high includes it.
By their numbers in this assay, from the lowest: compounds 2, 3 and 1 (each within the scatter of the next).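

In this assay, among these compounds, the exchange of 4-(methylsulfanyl)phenyl for 4-(dimethylamino)phenyl gives a 1.1-fold higher number from compound 2 to compound 3 (0.05 log units; within the scatter) and is the first one-place comparison. At this position, para to a large group, methylsulfanyl and dimethylamino do not separate, so the two groups are interchangeable here on the evidence of this one pair.

Open, from the compounds shown here alone, is whether a primary amine, a carboxylic acid or a longer chain at the same place would separate from these two groups, and whether the same exchange reads alike with cyclohexyl on the amide carbonyl. No measured evidence bears on the reason for this result.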